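A few compounds are considered here, and "the series" means these few. Any claim that something is new, unique, unknown or untested is made for them only; others in the source may bear on it.

Compound 3 `COc1ccc(-c2cn(-c3cccc(C(=O)/C=C/c4ccc(O)c(OC)c4)c3)c(=O)[nH]2)cc1` gives 3150 nM in a functional assay on HCT-15 cells (Homo sapiens) for inhibition (on this read-out lower numbers stand for stronger inhibition of growth and higher numbers for weaker inhibition of growth), the second highest of the three numbers recorded. Its closest neighbour is compound 1 `COc1cc(/C=C/C(=O)c2cccc(-n3cc(-c4ccc(Cl)cc4)[nH]c3=O)c2)cc(OC)c1OC`, which gives 3850 nM, a gap that lies within the scatter; the furthest is compound 2 `COc1cc(/C=C/C(=O)c2cccc(-n3cc(-c4ccccc4)[nH]c3=O)c2)cc(OC)c1OC`, which gives 1130 nM, a gap beyond the scatter. For the measured compounds named here, the only single-point step measured so far, a 3.4-fold lower number from compound 1 to compound 2 (0.53 log units; beyond the scatter), concerns hydrogen in place of chloro on an aromatic carbon and is a modest one.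

Compound 4 `COc1ccc(-c2cn(-c3cccc(C(=O)/C=C/c4cc(OC)c(OC)c(OC)c4)c3)c(=O)[nH]2)cc1` differs from compound 3 by 3,4,5-trimethoxyphenyl in place of 4-hydroxy-3-methoxyphenyl on a double-bonded chain carbon bound to a double-bonded chain carbon. Going by the values given here, no measured step covers an exchange of this kind: the step from compound 1 to compound 2 touches a different part of the molecule, and the two compounds that already carry the 3,4,5-trimethoxyphenyl group, compound 1 and compound 2, differ from compound 4 elsewhere as well. The bearing of the change on this assay is therefore unknown, and no step beyond the scatter is expected in either direction; the estimated change is a 1.4-fold lower number from compound 3 to compound 4 (0.14 log units; within the scatter). For compound 4 the expected value in this assay is 2300 nM, within a range from 700 nM to 7500 nM.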

Compound 4, concentration for 50% growth inhibition: 1380 nM
The estimate for compound 4 lay 1.7-fold (0.22 log units) above the measured number, and the stated range covers the measured number.
By their numbers in this assay, from the lowest: compounds 2 and 4 (each within the scatter of the next); then compounds 3 and 1 (each within the scatter of the next).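

For the compounds shown here, at the double-bonded chain carbon, 3,4,5-trimethoxyphenyl in place of 4-hydroxy-3-methoxyphenyl gives the first measured step at this end of the molecule in this assay (a 2.3-fold lower number from compound 3 to compound 4 (0.36 log units; beyond the scatter)), and this step lies beyond the scatter. With 3,4,5-trimethoxyphenyl in place, the aromatic carbon at the other end of the molecule separates methoxy from chloro (a 2.8-fold lower number from compound 1 to compound 4 (0.45 log units; beyond the scatter)) but not methoxy from hydrogen (a 1.2-fold higher number from compound 2 to compound 4 (0.09 log units; within the scatter)), so chloro alone stands apart among these three groups. No available evidence bears on these steps. The exchange replaces 4-hydroxy-3-methoxyphenyl as a whole, so the compounds shown cannot separate the loss of the hydroxy group from the gain in methoxy groups. They also leave open how an amine or a carboxylic acid would fare on either aromatic ring.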